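Vinyl dihydrofuran carboxamides tested for cytotoxicity

A few compounds are considered here, and "the series" means these few. Any claim that something is new, unique, unknown or untested is made for them only; others in the source may bear on it.

The series shares a core in which a vinyl-substituted dihydrofuran carries an amide and an aryl group, and it was tested in a functional assay on QGY7701 cells (Homo sapiens) for cytotoxicity, read by MTT assay, with a stated time of 24 h; a higher number here means a weaker inhibitor, a lower number a stronger inhibitor. Compound 1 `C=CC1=C(C(=O)NCCC)C(c2ccc(F)cc2)OC1` gives > 100000 nM, which is a limit of the assay rather than a number. Compound 2 `C=CC1=C(C(=O)NCC(C)C)C(c2ccc(F)cc2)OC1` gives > 100000 nM, again a limit. Compound 3 `C=CC1=C(C(=O)NCCC)C(c2ccc(OC)cc2)OC1` gives > 100000 nM, also a limit. The change from compound 1 to compound 2 is methyl in place of hydrogen on a saturated chain carbon bound to two saturated chain carbons; the step that the two limits leave unreadable from compound 1 to compound 2 cannot be read, because of the limit of > 100000 nM in this assay, at which 3 of the 3 values shown sit. Compound 3 differs from compound 1 by methoxy in place of fluoro on an aromatic carbon. Compound 4 `C=CC1=C(C(=O)NCC(C)C)C(c2ccc(OC)cc2)OC1` is not yet measured; it differs from compound 3 by methyl in place of hydrogen on a saturated chain carbon bound to two saturated chain carbons, the same change as that from compound 1 to compound 2. Among the compounds with values here, since the step from compound 1 to compound 2 could not be read, the expected step that the limit leaves unreadable from compound 3 to compound 4 rests on the one point that compound 3 gives > 100000 nM and the two companions sit at the same limit. Compound 4 is therefore expected to give roughly 150000 nM, most likely reported as a limit, within 50000 nM to 500000 nM.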

Compound 4, half-maximal inhibitory concentration: > 100000 nM
Compound 4 ended at the assay's limit; the forecaster's own chance of this, stated with the estimate: 85%; the middle value does not contradict the limit.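

In this assay compound 4 gives > 100000 nM as a limit and not a number. Neither the step from compound 3 to compound 4 nor the one from compound 2 to compound 4 can be read, because all the compounds stand at one limit: the limit of > 100000 nM in this assay, at which 4 of the 4 values shown sit.
The compounds shown leave open whether either change alters cytotoxicity at all.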